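The source may hold more compounds than are shown below. What is called first, only, known or untested is meant among the compounds shown, and "the series" means these compounds.

Working notes on the series. Compound 1 `O=S(=O)(c1ccccc1)c1cn(C2CCNCC2)c2ccccc12` has "not determined" (no result reported) in a functional assay on HeLa cells for agonist activity at 5-hydroxytryptamine receptor 6 (Homo sapiens), read by cAMP accumulation and immunoassay, with a stated time of 10 min (on this read-out lower numbers stand for an effect already at smaller amounts and higher numbers for an effect only at larger amounts of compound), so no result is available for it. Compound 2 `O=S(=O)(c1cccc(F)c1)c1cn(C2CCCNC2)c2ccccc12` gives 56 nM in this assay, and compound 3 `O=S(=O)(c1ccccc1)c1cn(C2CCNC2)c2ccccc12` gives 60 nM; these two numbers lie within the scatter of each other, so no order between them can be stated, and compound 3 stands level with the only other measured entry. Compound 4 `O=S(=O)(c1cccc(F)c1)c1cn(C2CCNC2)c2ccccc12` differs from compound 3 by fluoro in place of hydrogen on an aromatic carbon, the same difference read one bond further out being phenyl to 3-fluorophenyl. For the measured compounds named here, no measured pair shows this change alone; compound 2 carries the 3-fluorophenyl group but also differs from compound 3 elsewhere, so its number gives only loose guidance. The expected step is a 1.1-fold lower number from compound 3 to compound 4 (0.04 log units; within the scatter), none beyond the scatter. Compound 4 is estimated at 55 nM in this assay, with a range from 25 nM to 120 nM.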

Compound 4, half-maximal effective concentration: 68 nM
Estimate against measurement, compound 4: 1.2-fold (0.09 log units) below; the range from low to high includes it.
By their numbers in this assay, from the lowest: compounds 2, 3 and 4 (each within the scatter of the next).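

In this assay, fluoro in place of hydrogen on an aromatic carbon, phenyl to 3-fluorophenyl, can now be read alone: the change gives a 1.1-fold higher number from compound 3 to compound 4 (0.05 log units; within the scatter) and so does not separate the two compounds. With the 3-fluorophenyl group held constant, pyrrolidin-3-yl in place of piperidin-3-yl on the aromatic nitrogen gives a 1.2-fold higher number from compound 2 to compound 4 (0.08 log units; within the scatter) and likewise separates nothing. No available data bear on the reason for either result.

As far as these compounds go, whether methoxy or chloro on this aromatic carbon would give a number beyond the scatter stays open. So does the effect of a methyl group on the ring amine.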